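The source may report more compounds than this note shows. Statements on the series, on what has been measured and on what is new or still open speak of the compounds shown alone.

Working notes on the series. In a functional assay (trachea) with Rattus norvegicus as the target (a lower number here means a less potent compound, a higher number a more potent compound, by a factor of ten per unit of this negative logarithm), compound 1 `CC(=O)c1ccc2c(c1)C(n1ccccc1=O)=CC(C)(C)O2` gives 6.65. Compound 2 `CCC(=O)c1ccc2c(c1)C(n1ccccc1=O)=CC(C)(C)O2` gives 5.85 in this assay, and compound 3 `CC1(C)C=C(n2ccccc2=O)c2cc(C(=O)c3ccc(O)cc3)ccc2O1` gives 5.87. Compound 3 thus stands second highest of the three numbers: compound 2 is nearest, within the scatter, and compound 1 is furthest, beyond it. Two measured steps end at compound 3, a number 0.78 log units lower from compound 1 to compound 3 (beyond the scatter) and a number 0.02 log units higher from compound 2 to compound 3 (within the scatter), and only the first is beyond the scatter.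

Compound 4 `CC1(C)C=C(n2ccccc2=O)c2cc(C(=N)NO)ccc2O1` has not yet been measured in this assay. Its change from compound 3 is a group of 4 heavy atoms (1 carbon, 2 nitrogen, 1 oxygen; no ring) in place of a group of 9 heavy atoms (7 carbon, 2 oxygen; one six-membered aromatic ring of carbon only), on an aromatic carbon. The measured steps at this position only exchange the group on the carbonyl carbon, so they bear on the step to compound 4 loosely: methyl on the carbonyl carbon gives the highest number, while ethyl and 4-hydroxyphenyl sit lower. Going by the values given here, the entering group is smaller than the leaving one, so a move back toward the level of compound 1 is plausible, though with no direct precedent the expectation is wide. Compound 4 is expected to give 6.1 in this assay, within 5.2 to 7. The expected step is a number 0.23 log units higher from compound 3 to compound 4 (within the scatter).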

Compound 4, logarithm of the reciprocal of the active concentration, log(1/C): 5.51
Compound 4: the middle estimate sits 0.59 log units above what was measured; the measured number falls inside the stated range.
By their numbers in this assay, from the lowest: compound 4; then compounds 2 and 3 (each within the scatter of the next); then compound 1.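

Compound 4 is the only compound shown without a carbonyl on this aromatic carbon, and it lies below all three carbonyl compounds in this assay: a number 0.36 log units lower from compound 3 to compound 4 (beyond the scatter), a number 0.34 log units lower from compound 2 to compound 4 (beyond the scatter) and a number 1.14 log units lower from compound 1 to compound 4 (beyond the scatter). The step from compound 2 exchanges one group of 4 heavy atoms for another and still lies beyond the scatter, so heavy-atom count alone does not set the number at this position. Nothing shown accounts for the lower number of compound 4.

As far as these compounds go, whether a carboxylic acid, a primary amide or a nitrile on this aromatic carbon would lie nearer compound 1 or compound 4 remains open. Also open, from the compounds shown here alone, is whether the same order of groups would hold on a different core.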